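The compounds below may be only part of what the source reports. "The series", "measured", "known", "first", "only" and "open" are said of these compounds alone.

Measured so far in a functional assay on LoVo cells (Homo sapiens) for cytotoxicity, read by colorimetric assay and MTT assay; a higher number here means a weaker inhibitor, a lower number a stronger inhibitor:
- compound 1 `COc1ccc2cc(-c3ccccc3)c(O)nc2c1`: 10000 nM
- compound 2 `COc1cc(OC)c2cc(-c3ccc(OCc4ccccc4)cc3)c(O)nc2c1`: 10000 nM
- compound 3 `CCOC(=O)Cn1c(=O)c(-c2ccc(OC)cc2)cc2c(OC)cc(OC)cc21`: 10000 nM

Within the data shown here, compound 3, at 10000 nM, stands level with both other compounds, so the series so far shows no spread in this assay. Among the measured compounds shown here, of these three, only compound 3 carries the (ethoxycarbonyl)methyl group, and no measured pair differs in one place. The data therefore give no direct reading of what a change at this group does.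

The next compound is compound 4 `COc1ccc(-c2cc3c(OC)cc(OC)cc3n(CC#N)c2=O)cc1`, with cyano in place of ethoxycarbonyl on a saturated chain carbon bound to an aromatic nitrogen. The same difference, cut one bond further out, reads (ethoxycarbonyl)methyl to cyanomethyl.

With compound 3 at 10000 nM as the only close reference, the expected 1.1-fold lower number from compound 3 to compound 4 (0.05 log units; within the scatter) is none beyond the scatter, with a small chance of a stronger result. The estimate for compound 4 is 9000 nM, with an expected range of 3000 nM to 15000 nM.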

Compound 4, half-maximal inhibitory concentration: 10000 nM
Compound 4: the middle estimate sits 1.1-fold (0.05 log units) below what was measured; measured number inside the range.
By their numbers in this assay, from the lowest: compounds 1, 2, 3 and 4 (each within the scatter of the next).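

In this assay, among these compounds, the first one-place comparison of the series reads no change at the digits printed from compound 3 to compound 4 (within the scatter) and concerns the group on a saturated chain carbon bound to an aromatic nitrogen. At this place, ethoxycarbonyl and cyano therefore cannot be told apart in this assay, so the ethoxycarbonyl group is not needed for the reading of compound 3, and the step shows no gain from the smaller cyano group. Nothing on hand accounts for this outcome.

Still open, from the compounds shown here alone, is whether a carboxylic acid, a primary amide, an amine or a longer chain ending in any of these at the same place would give a different number from compound 3. With every compound shown sharing one printed value, the compounds shown also leave open which change to the shared core, if any, would separate one compound from another in this assay.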